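Quinolinylmethoxy Analogue of a Chromone Series: An Expectation

The source may hold more compounds than are shown below. What is called first, only, known or untested is meant among the compounds shown, and "the series" means these compounds.

Measured compounds:
Compound 1 `CCN(CC)C(=O)COc1ccc2c(=O)cc(-c3cc(C(C)(C)C)c(O)c(C(C)(C)C)c3)oc2c1` — 3000 nM
Compound 2 `CCCCCCOc1ccc2c(=O)cc(-c3cc(C(C)(C)C)c(O)c(C(C)(C)C)c3)oc2c1` — 5000 nM
Compound 3 `CN(C)CCCOc1ccc2c(=O)cc(-c3cc(C(C)(C)C)c(O)c(C(C)(C)C)c3)oc2c1` — 700 nM

In a functional assay for inhibition (a lower number here means a stronger inhibitor, a higher number a weaker inhibitor), compound 1 gives 3000 nM, the second highest of the three numbers. Compound 2 sits closest to it, a 1.7-fold higher number from compound 1 to compound 2 (0.22 log units; within the scatter), while compound 3 lies furthest away, a 4.3-fold lower number from compound 1 to compound 3 (0.63 log units; beyond the scatter). Going by the values given here, the one step between compound 2 and compound 3 is also modest, a 7.1-fold lower number from compound 2 to compound 3 (0.85 log units; beyond the scatter).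

Compound 4 `CC(C)(C)c1cc(-c2cc(=O)c3ccc(OCc4ccc5ccccc5n4)cc3o2)cc(C(C)(C)C)c1O` has not yet been measured in this assay. It differs from compound 1 in one place:

quinolin-2-yl in place of diethylcarbamoyl on a saturated chain carbon bound to an oxygen on an aromatic ring

Among the compounds with values here, two measured steps bear on this change, as both leave the same position of compound 1. The step to compound 2, in which the same group gives way to a plain chain, stays within the scatter. The step to compound 3, in which it gives way to a group holding a nitrogen, reaches a modest lowering. The entering quinolin-2-yl group again holds a nitrogen as a hydrogen-bond acceptor, but it is aromatic and bicyclic, unlike anything among the three measured compounds, so the data give only a loose guide.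

Compound 4 is therefore expected to land near compound 1, with a step of a 1.5-fold lower number from compound 1 to compound 4 (0.18 log units; within the scatter), leaning slightly toward a lower number but not beyond the scatter with confidence. The estimated value for compound 4 is 2000 nM, within a range from 500 nM to 8000 nM.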

Compound 4, half-maximal inhibitory concentration: 3000 nM
Compound 4: the middle estimate sits 1.5-fold (0.18 log units) below what was measured; measured number inside the range.
By their numbers in this assay, from the lowest: compound 3; then compounds 1, 4 and 2 (each within the scatter of the next).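

In this assay the step to the quinolin-2-yl group, with its two six-membered aromatic rings, gives no change at the digits printed from compound 1 to compound 4 (within the scatter) and, set against the plain chain, a 1.7-fold lower number from compound 2 to compound 4 (0.22 log units; within the scatter), so this position on the saturated chain carbon accepts a bicyclic aromatic group, an amide and a pentyl group without any step beyond the scatter. A nitrogen in the entering group is not enough by itself to reach the number of compound 3, since the change to compound 4 gives a 4.3-fold higher number from compound 3 to compound 4 (0.63 log units; beyond the scatter) and the quinolin-2-yl group holds a nitrogen just as the 2-(dimethylamino)ethyl group does; among the four compounds, only compound 3 stands apart from the rest beyond the scatter. Nothing measured here accounts for that difference.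

The compounds shown leave open whether the lower number of compound 3 belongs to the dimethylamino group itself or to its place along the chain, which a diethylamino or morpholine group on the same chain, or a dimethylamino group on a shorter or longer chain, would separate. They also leave open whether a single pyridin-2-yl ring would behave as the quinolin-2-yl group does.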